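Two Inactive Compounds and a Chloro-for-Methyl Exchange

This account rests on a few compounds, and the source may have more. Where it says the series, first, only, none or still open, it means among the compounds named here.

Compound 1, `CS(=O)(=O)c1ccc(Nc2ncc(F)c(Nc3nc4ccc(Cl)cc4s3)n2)cc1`: > 50000 nM
Compound 2, `Cc1ccc2nc(Nc3ccnc(Nc4ccc(S(C)(=O)=O)cc4)n3)sc2c1`: > 50000 nM

Both compounds were tested in a functional assay on PC-3 cells (Homo sapiens) for antiproliferative activity, read by MTT assay, with a stated time of 48 h; a higher number here means a weaker inhibitor, a lower number a stronger inhibitor. Compound 1 reports only > 50000 nM in this assay, which is a limit of the assay and not a measured number. Compound 2 likewise reports only > 50000 nM in this assay, again a limit rather than a number. Compound 2 therefore stands exactly where compound 1 stands: at the limit, with no activity detected, and nothing on the numbers shown separates the two compounds because the limit of > 50000 nM in this assay, at which 2 of the 2 values shown sit, is where both of them sit.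

Compound 3, `CS(=O)(=O)c1ccc(Nc2nccc(Nc3nc4ccc(Cl)cc4s3)n2)cc1`, differs from compound 2 in a single place: chloro in place of methyl on an aromatic carbon. Going by the values given here, no measured step of this kind is available here. With both neighbours inactive, the expected step of a number no higher from compound 2 to compound 3 (the limit leaves the size open) is none beyond the usual scatter, and the most likely outcome is that the assay again reports only a limit. Compound 3 is expected to give 50000 nM in this assay, within a range from 20000 nM to 150000 nM.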

Compound 3, half-maximal inhibitory concentration: > 50000 nM
Compound 3 ended at the assay's limit; the forecaster's own chance of this, stated with the estimate: 80%; the middle value sits exactly at the limit.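

The steps from compound 2 to compound 3 and from compound 1 to compound 3 cannot be read, because all three compounds give only the same limit and no measured number: the limit of > 50000 nM in this assay, at which 3 of the 3 values shown sit.

On these data alone, whether chloro in place of methyl, or hydrogen in place of fluoro, changes activity at all in this assay stays open.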